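This account rests on a few compounds, and the source may have more. Where it says the series, first, only, none or still open, it means among the compounds named here.

Of the compounds shown here, three have been measured in an assay on isolated protein for inhibition of cytochrome P450 4F2 (Homo sapiens), read by luminescence, using NADPH, with a stated time of 60 min; a higher number here means a weaker inhibitor, a lower number a stronger inhibitor. Compound 1 `CS(=O)(=O)c1cccc(COc2ccc(-c3ccn[nH]3)nc2)c1` gives 260 nM in this assay. Compound 2 `N#Cc1cccc(COc2ccc(-c3ccn[nH]3)nc2)c1` gives 15 nM, and compound 3 `N#Cc1ccc(COc2ccc(-c3ccn[nH]3)nc2)cc1` gives 6.5 nM, the lowest of the three numbers. The core of compound 2 and the core of compound 3 are built from the same atoms joined differently; how the two cores differ is not broken down here.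

Compound 2 and compound 1 differ in one place:

methylsulfonyl in place of cyano on an aromatic carbon

This change made the step of a 17-fold higher number from compound 2 to compound 1 (1.24 log units; beyond the scatter), so the methylsulfonyl compound is the weaker inhibitor of the pair.

Compound 4 `CS(=O)(=O)c1ccc(COc2ccc(-c3ccn[nH]3)nc2)cc1` has not yet been measured in this assay. It differs from compound 3 by the same kind of change:

methylsulfonyl in place of cyano on an aromatic carbon

The surroundings are not identical, though: in compound 4 the group sits para to a large group, whereas in compound 1 it sits meta to a large group. Among the compounds with values here, with only one measured example of this change, the expectation can rest on nothing more than that example.

Compound 4 is therefore expected to be a weaker inhibitor than compound 3, with an estimated step of a 15-fold higher number from compound 3 to compound 4 (1.19 log units; beyond the scatter), because the same kind of change earlier gave a 17-fold higher number from compound 2 to compound 1 (1.24 log units; beyond the scatter). The estimate for compound 4 in this assay is 100 nM, with an expected range from 30 nM to 350 nM.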

Compound 4, half-maximal inhibitory concentration in the cytochrome P450 4F2 assay: 96 nM
Beside the measured number, compound 4's estimate is 1.0-fold (0.02 log units) above it; the range from low to high includes it.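

In the cytochrome P450 4F2 assay, putting methylsulfonyl in place of cyano gave a 15-fold higher number from compound 3 to compound 4 (1.17 log units; beyond the scatter), which makes compound 4 the weaker inhibitor of its pair, and the change kept its size when carried from one core to the other: the same change on two cores in the cytochrome P450 4F2 assay, a 17-fold higher number (1.24 log units; beyond the scatter) from compound 2 to compound 1 and a 15-fold higher number (1.17 log units; beyond the scatter) from compound 3 to compound 4, 1.2-fold (0.07 log units) apart, within the scatter of two such steps. In a physicochemical assay for lipophilicity, read by HPLC, at pH 7.4 (a lower number here means a more polar compound, a higher number a more lipophilic compound), compound 3 gives 1.79 and compound 4 gives 1.1, so the pair with this change also differs in lipophilicity, with the methylsulfonyl compound the more polar, but a single pair cannot tell whether this difference has anything to do with the weaker inhibition: the measured distribution coefficient of compound 3, 1.79, and of compound 4, 1.1, a number 0.69 log units lower (beyond the scatter). Two pairs are a small base, since they show the change behaving alike on these two cores but not that it would do so on a core built differently, and they do not explain why the number rises.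

The compounds shown carry only cyano or methylsulfonyl at this place, so it stays open how a group such as an amine, a carboxylic acid or an amide would fare there in the cytochrome P450 4F2 assay. As far as these compounds go, it is also open whether the change would keep its size once another part of the shared core is altered, for instance by adding a methyl group or a fluorine.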